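Cyclohexyl Amide Analogue in a Shared Core Series

This account rests on a few compounds, and the source may have more. Where it says the series, first, only, none or still open, it means among the compounds named here.

Compound 1 `Cc1ccc(-n2cc(Cn3nc(N)c4c(C(F)(F)F)cc(-c5ccccc5)nc43)nn2)cc1`, compound 2 `COc1ccc(NC(=O)Cn2cc(Cn3nc(N)c4c(C(F)(F)F)cc(-c5ccccc5)nc43)nn2)cc1` and compound 3 `Nc1nn(Cc2cn(CC(=O)Nc3cccc(F)c3)nn2)c2nc(-c3ccccc3)cc(C(F)(F)F)c12` share one core and differ only in the group on an aromatic nitrogen. In a functional assay on THP-1 cells (Homo sapiens) for cytotoxicity, read by MTT assay, with a stated time of 24 h (a lower number here means a stronger inhibitor, a higher number a weaker inhibitor), compound 1 gives 98.6 ug/mL, compound 2 gives 56.7 ug/mL and compound 3 gives 99.5 ug/mL. Compound 3 carries the highest of the three numbers, yet each step among them lies within the scatter: a 1.7-fold lower number from compound 1 to compound 2 (0.24 log units; within the scatter), a 1.0-fold higher number from compound 1 to compound 3 (0.00 log units; within the scatter) and a 1.8-fold higher number from compound 2 to compound 3 (0.24 log units; within the scatter). Compound 4 `Nc1nn(Cc2cn(CC(=O)NC3CCCCC3)nn2)c2nc(-c3ccccc3)cc(C(F)(F)F)c12` differs from compound 3 by cyclohexyl in place of 3-fluorophenyl on an amide-type nitrogen. Within the data shown here, the one step that alters the group on the amide-type nitrogen stayed within the scatter, so for compound 4 the expected step is a 1.1-fold lower number from compound 3 to compound 4 (0.04 log units; within the scatter), nothing beyond the scatter. Compound 4 is therefore estimated at 90 ug/mL, with a range from 50 ug/mL to 160 ug/mL.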

Compound 4, half-maximal inhibitory concentration: 64.8 ug/mL
Beside the measured number, compound 4's estimate is 1.4-fold (0.14 log units) above it, and the stated range covers the measured number.
By their numbers in this assay, from the lowest: compounds 2, 4, 1 and 3 (each within the scatter of the next).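

In this assay, among these compounds, cyclohexyl in place of 3-fluorophenyl gives a 1.5-fold lower number from compound 3 to compound 4 (0.19 log units; within the scatter) and cyclohexyl in place of 4-methoxyphenyl gives a 1.1-fold higher number from compound 2 to compound 4 (0.06 log units; within the scatter) on the amide-type nitrogen, so a non-aromatic ring of carbon stands here with no step beyond the scatter, where the earlier compounds held only aromatic rings. On the aromatic nitrogen, (cyclohexylcarbamoyl)methyl in place of 4-methylphenyl gives a 1.5-fold lower number from compound 1 to compound 4 (0.18 log units; within the scatter) and also stays within the scatter. No measured evidence bears on this result.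

The compounds shown leave open whether an amine, a carboxylic acid or a longer chain on the amide-type nitrogen would give a step beyond the scatter.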